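The source may hold more compounds than are shown below. What is called first, only, known or untested is meant among the compounds shown, and "the series" means these compounds.

Working notes on a short series built on one shared core. Compound 1 `Cc1cc(NC(=O)Nc2ccccc2OC(F)(F)F)c2ccccc2n1`, compound 2 `COc1ccccc1NC(=O)Nc1cc(C)nc2ccccc12` and compound 3 `COc1cccc(NC(=O)Nc2cc(C)nc3ccccc23)c1` have been measured in an ADME assay on BJ cells (Homo sapiens) for cytotoxicity, with a stated time of 72 h; a lower number here means that less compound is needed, a higher number that more compound is needed for the effect; compound 4 `Cc1cc(NC(=O)Nc2cccc(OC(F)(F)F)c2)c2ccccc2n1` has not.

In this assay compound 1 reaches only the limit of the assay, > 25000 nM. Compound 2 likewise returns only the limit > 25000 nM in this assay. Among the compounds with values here, compound 3 is the single compound of the three with a number in this assay, giving 27000 nM.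

Compound 2 and compound 3 are made of the same atoms joined differently; the difference between the two cores is not broken down here. Going from compound 2 to compound 1 the change is trifluoromethyl in place of methyl on an oxygen on an aromatic ring, and the step that the two limits leave unreadable from compound 2 to compound 1 stays unreadable because the limit of > 25000 nM in this assay, at which 2 of the 3 values shown sit, hides both ends of it.

The change from compound 3 to compound 4 is the same one, (trifluoromethyl in place of methyl on an oxygen on an aromatic ring), made on the other core. Within the data shown here, the one measured instance of it, a step that the two limits leave unreadable from compound 2 to compound 1, gives no size, so nothing points away from the region where compound 3 already sits with 27000 nM. For compound 4 the expected step is therefore a 1.1-fold higher number from compound 3 to compound 4 (0.05 log units; within the scatter), with a real chance that the assay again reports only a limit. The estimate for compound 4 in this assay is 30000 nM, expected to fall between 14000 nM and 60000 nM.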

Compound 4, half-maximal effective concentration in the BJ assay: 25000 nM
For compound 4 the middle estimate is 1.2-fold (0.08 log units) above the measured one; the measured number falls inside the stated range.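

In the BJ assay compound 3 gives 27000 nM and compound 4 gives 25000 nM. In the BJ assay the change from methoxy to trifluoromethoxy on the core of compound 3 gives a 1.1-fold lower number from compound 3 to compound 4 (0.03 log units; within the scatter), so on this core the two compounds cannot be told apart in that read-out. In a physicochemical assay for solubility, at pH 7.4 (a lower number here means a less soluble compound, a higher number a more soluble compound), compound 3 gives 1200 nM and compound 4 gives 600 nM. In the physicochemical assay the same change gives a 2.0-fold lower number from compound 3 to compound 4 (0.30 log units; within the scatter), which is again within the scatter, so neither assay separates the pair on this core. This is one readable instance and does not show that the change carries from one core to the other, since the matching step from compound 2 to compound 1 cannot be read, and that leaves no second size to set against this one because both compounds return only a limit of the assay: the limit of > 25000 nM in the BJ assay, at which 2 of the 4 values shown sit.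

The compounds shown leave open how a group other than methoxy or trifluoromethoxy, such as an amine or a carboxylic acid at the same place on the aromatic ring, would read in the BJ assay and in the physicochemical assay. Within the data shown here, also open is how the change reads in the physicochemical assay on the core of compound 1, where the series offers no pair to compare.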